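Replacing trifluoromethoxy with iodo in a growth inhibitor

The compounds below may be only part of what the source reports. "The series", "measured", "known", "first", "only" and "open" are said of these compounds alone.

Measured so far in a functional assay on DU-145 cells (Homo sapiens) for inhibition, read by trypan blue exclusion, with a stated time of 96 h (on this read-out higher numbers stand for weaker inhibition of growth and lower numbers for stronger inhibition of growth), are three compounds that differ in one region.
- Compound 1 `O=C(/C(=C\c1ccc(Cl)cc1)S(=O)(=O)c1ccc(Br)cc1)c1ccc(Br)cc1` gives 50000 nM
- Compound 2 `COc1ccc(/C=C(\C(=O)c2ccc(Br)cc2)S(=O)(=O)c2ccc(Br)cc2)c(F)c1` gives 10000 nM
- Compound 3 `O=C(/C(=C\c1ccc(OC(F)(F)F)cc1)S(=O)(=O)c1ccc(Br)cc1)c1ccc(Br)cc1` gives 25000 nM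

Compound 3 cannot be told apart from compound 1 on these numbers (a 2.0-fold lower number from compound 1 to compound 3 (0.30 log units; within the scatter)). Compound 2 gives a lower number than compound 3, beyond the scatter.

Compound 4 `O=C(/C(=C\c1ccc(I)cc1)S(=O)(=O)c1ccc(Br)cc1)c1ccc(Br)cc1` carries iodo in place of trifluoromethoxy on an aromatic carbon. Among the measured compounds shown here, no iodo compound has been measured yet, so the closest guide is the swap at the same carbon that links compound 1 and compound 3, and that step stayed within the scatter. The step to compound 2 is larger (a 5.0-fold lower number from compound 1 to compound 2 (0.70 log units; beyond the scatter)), but it changes more of the ring, so it bears less directly on this swap. In this assay, no step beyond the scatter is therefore expected, in either direction.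

The expected step is small (a 1.2-fold higher number from compound 3 to compound 4 (0.08 log units; within the scatter)). Compound 4 is estimated at about 30000 nM (expected range 10000 nM to 80000 nM).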

Compound 4, concentration for 50% growth inhibition: 1000 nM
Compound 4: the middle estimate sits 30-fold (1.48 log units) above what was measured; the whole stated range lies above it.
By their numbers in this assay, from the lowest: compound 4; then compound 2; then compounds 3 and 1 (each within the scatter of the next).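

In this assay, among the compounds shown here, the group at this ring carbon matters far more than the earlier compounds showed: iodo in place of trifluoromethoxy gives a large step (a 25-fold lower number from compound 3 to compound 4 (1.40 log units; beyond the scatter)), and iodo in place of chloro gives a larger one on paper (a 50-fold lower number from compound 1 to compound 4 (1.70 log units; beyond the scatter)). Compound 1 and compound 3 had stayed within the scatter of each other, so a swap at this carbon had looked unlikely to count for much, yet the 4-iodophenyl group also outdoes the 2-fluoro-4-methoxyphenyl group (a 10-fold lower number from compound 2 to compound 4 (1.00 log units; beyond the scatter)). What sets iodo apart from the other groups has no measured explanation here.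

As far as these compounds go, whether an amine, a carboxylic acid or a longer chain at this same carbon would match iodo stays open. So does whether the gain would hold in other cell lines.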